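The source may report more compounds than this note shows. Statements on the series, on what has been measured and on what is new or still open speak of the compounds shown alone.

Compound 1 `c1ccc(CNCC2CCN(CCCc3c[nH]c4ccc(-n5cnnc5)cc34)CC2)cc1`: 28 nM
Compound 2 `CN(CC1CCN(CCCc2c[nH]c3ccc(-n4cnnc4)cc23)CC1)C(=O)Nc1ccccc1`: 6.2 nM
Compound 3 `C[C@@H](NCC1CCN(CCCc2c[nH]c3ccc(-n4cnnc4)cc23)CC1)c1ccccc1`: 14 nM

All three share one core and were tested in an assay on CHO cells for displacement of a labelled ligand from 5-hydroxytryptamine receptor 1B (Homo sapiens); a lower number here means a stronger inhibitor, a higher number a weaker inhibitor. Compound 3 gives 14 nM and so holds the second highest of the three numbers. Compound 2, at 6.2 nM, sits beyond the scatter below it (a 2.3-fold higher number from compound 2 to compound 3 (0.35 log units; beyond the scatter)), whereas compound 1, at 28 nM, lies within the scatter of it (a 2.0-fold lower number from compound 1 to compound 3 (0.30 log units; within the scatter)).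

Compound 4 `CC(=O)Nc1ccc(CNCC2CCN(CCCc3c[nH]c4ccc(-n5cnnc5)cc34)CC2)cc1` is the next step from compound 3: 4-acetamidobenzyl in place of 1-phenylethyl on an amine nitrogen. Two parts make up this change. The loss of the methyl on the saturated chain carbon is the reverse of the step from compound 1 to compound 3, which stayed within the scatter (a 2.0-fold lower number from compound 1 to compound 3 (0.30 log units; within the scatter)). The acetamido on the aromatic ring has no measured precedent among these compounds; the only other variation at that amine, a 4.5-fold lower number from compound 1 to compound 2 (0.65 log units; beyond the scatter), was a modest one. Compound 4 is therefore expected to stay close to compound 3, with a 1.4-fold higher number from compound 3 to compound 4 (0.15 log units; within the scatter) and an estimated value of 20 nM, between 6 nM and 60 nM.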

Compound 4, half-maximal inhibitory concentration: 8.9 nM
Compound 4: middle estimate off by 2.2-fold (0.35 log units), on the high side; the range from low to high includes it.
By their numbers in this assay, from the lowest: compounds 2, 4, 3 and 1 (each within the scatter of the next, the first and the last beyond it).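

In this assay, for the compounds shown here, the acetamido group gives the first reading of a substituent on this aromatic ring, and the step is a modest gain beyond the scatter (a 3.1-fold lower number from compound 1 to compound 4 (0.50 log units; beyond the scatter)). The 4-acetamidobenzyl group on the amine nitrogen, with its hydrogen-bond donor and acceptor, also stays within the scatter of both neighbouring variations (a 1.6-fold lower number from compound 3 to compound 4 (0.20 log units; within the scatter); a 1.4-fold higher number from compound 2 to compound 4 (0.16 log units; within the scatter)), so this position accepts the larger group with no loss in this assay. Nothing measured here accounts for these steps.

The compounds shown leave open whether a methoxy group or a sulfonamide in place of acetamido would give the same gain. They also leave open what happens when acetamido and the methyl of 1-phenylethyl are combined in one compound.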